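Working notes: from 3-chlorophenyl to 2-chlorophenyl

The source may report more compounds than this note shows. Statements on the series, on what has been measured and on what is new or still open speak of the compounds shown alone.

Measured in a functional assay on SW480 cells (Homo sapiens) for cytotoxicity, read by MTT assay, with a stated time of 48 h; a higher number here means a weaker inhibitor, a lower number a stronger inhibitor:
- compound 1 `O=c1ccoc2cc(OCc3cn(Cc4ccc(Cl)cc4)nn3)ccc12`: > 100000 nM, a limit of the assay
- compound 2 `O=c1ccoc2cc(OCc3cn(Cc4ccc(F)cc4)nn3)ccc12`: 11200 nM
- compound 3 `O=c1ccoc2cc(OCc3cn(Cc4cccc(Cl)c4)nn3)ccc12`: 12900 nM

Within the data shown here, compound 3 cannot be told apart from the only other numeric value: a 1.2-fold higher number from compound 2 to compound 3 (0.06 log units; within the scatter). The next structure is compound 4 `O=c1ccoc2cc(OCc3cn(Cc4ccccc4Cl)nn3)ccc12`, with 2-chlorophenyl in place of 3-chlorophenyl on a saturated chain carbon bound to an aromatic nitrogen: 2-chlorophenyl in place of 3-chlorophenyl. The closest measured change is 3-chlorophenyl in place of 4-chlorophenyl, an at least 7.7-fold lower number from compound 1 to compound 3 (0.88 log units; beyond the scatter), so the choice of chlorophenyl isomer can matter in this assay. The halogen swap, an at least 8.9-fold lower number from compound 1 to compound 2 (0.95 log units; beyond the scatter), bears on it less directly. Among the measured compounds shown here, no measured compound carries 2-chlorophenyl, so only a modest step is expected, leaning towards a higher number. The estimated step is a 1.2-fold higher number from compound 3 to compound 4 (0.09 log units; within the scatter). Compound 4 is expected at 16000 nM, with an estimated range of 6000 nM to 60000 nM.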

Compound 4, half-maximal inhibitory concentration: 23500 nM
Beside the measured number, compound 4's estimate is 1.5-fold (0.17 log units) below it, within the range that was stated.
By their numbers in this assay, from the lowest: compounds 2, 3 and 4 (each within the scatter of the next, the first and the last beyond it). At a limit, above all of these: compound 1.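

In this assay, 2-chlorophenyl in place of 3-chlorophenyl gives a 1.8-fold higher number from compound 3 to compound 4 (0.26 log units; within the scatter), so these two chlorophenyl isomers cannot be told apart at this place. Against 4-fluorophenyl, 2-chlorophenyl gives a 2.1-fold higher number from compound 2 to compound 4 (0.32 log units; beyond the scatter), the first gap between two numeric values here that lies beyond the scatter, though a modest one. Compound 1 carries only a limit, so an at least 4.2-fold lower number from compound 1 to compound 4 (0.62 log units; beyond the scatter) is a bound and not a measured size: the limit of > 100000 nM in this assay, at which 1 of the 4 values shown sits.

Still open, on these data alone, is whether an amine or a carboxylic acid on the phenyl ring would shift the number. Also open, as far as these compounds go, is how a longer chain on the aromatic nitrogen would read in this assay.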